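Toward a Methyl-for-Dichloro Swap on a Shared Core

A few compounds are considered here, and "the series" means these few. Any claim that something is new, unique, unknown or untested is made for them only; others in the source may bear on it.

Compound 1 `C=CCn1c(=O)/c(=C\c2cccc(Cl)c2Cl)[nH]c(=O)/c1=C\c1ccccc1OC` is one of three compounds whose activity against lung cancer cells was examined. In a functional assay on A549 cells (Homo sapiens) for cytotoxicity, read by CCK-8 assay, with a stated time of 72 h (a lower number here means a stronger inhibitor, a higher number a weaker inhibitor), compound 1 gives 2300 nM. Among the two values that have numbers, compound 1 stands highest; its nearest neighbour is compound 2 `COc1ccccc1/C=c1\c(=O)[nH]/c(=C/c2cccc(Cl)c2Cl)c(=O)n1C`, which in this assay gives 200 nM, so that a 12-fold lower number from compound 1 to compound 2 (1.06 log units; beyond the scatter). Compound 3 `C=CCn1c(=O)/c(=C\c2cccc(Br)c2)[nH]c(=O)/c1=C\c1cccc(Br)c1` was reported as "not active" (no number reported) in this assay, with no number attached.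

Compound 4 `C=CCn1c(=O)/c(=C\c2cccc(C)c2)[nH]c(=O)/c1=C\c1ccccc1OC` has not yet been measured. It differs from compound 1 in one place: 3-methylphenyl in place of 2,3-dichlorophenyl on a double-bonded chain carbon bound to an aromatic carbon. Among the compounds with values here, no measured step bears directly on this change; the only step with a number concerns the group on the aromatic nitrogen, not this one. The result for compound 3, which carries halogen-bearing rings of a different pattern on both sides and the same allyl group as compound 1, offers only a faint hint that the halogen pattern matters. Compound 4 is therefore expected to be weaker than compound 1, with a 2.6-fold higher number from compound 1 to compound 4 (0.42 log units; beyond the scatter), and its estimated value in this assay is 6000 nM, between 1500 nM and 25000 nM.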

Compound 4, half-maximal inhibitory concentration: 22700 nM
For compound 4 the middle estimate is 3.8-fold (0.58 log units) below the measured one; measured number inside the range.
By their numbers in this assay, from the lowest: compound 2; then compound 1; then compound 4.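

The place on a double-bonded chain carbon bound to an aromatic carbon now has a measured step of its own: in this assay, 3-methylphenyl in place of 2,3-dichlorophenyl gives a 9.9-fold higher number from compound 1 to compound 4 (0.99 log units; beyond the scatter). Within the data shown here, until now, the only numbered change was the one on the aromatic nitrogen, a 12-fold lower number from compound 1 to compound 2 (1.06 log units; beyond the scatter), so the number is now seen to move in opposite directions with changes at two separate places around the shared core. Because the step removes both chlorines and adds a methyl group at once, it cannot assign the loss to any one of these, and nothing shown explains its size.

On these data alone, it remains open whether a plain phenyl group or an aminophenyl group at this place would stay closer to compound 1. Also open, as far as these compounds go, is whether 3-methylphenyl would carry the same penalty with the methyl group of compound 2 on the aromatic nitrogen.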